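Amine substituent series: cyclopentyl to 4-(trifluoromethyl)phenyl

The source may hold more compounds than are shown below. What is called first, only, known or untested is meant among the compounds shown, and "the series" means these compounds.

Measured in a functional assay on MCF7 cells (Homo sapiens) for inhibition, read by sulforhodamine B assay; on this read-out higher numbers stand for weaker inhibition and lower numbers for stronger inhibition:
Compound 1 `COc1ccc(NC2=CC(=O)c3c(nc4n3[C@H]3OC[C@@H](O)[C@H]3OC4)C2=O)cc1` gives 4470 nM.
Compound 2 `COc1ccccc1NC1=CC(=O)c2c(nc3n2[C@H]2OC[C@@H](O)[C@H]2OC3)C1=O` gives 6580 nM.
Compound 3 `O=C1C(NC2CCCC2)=CC(=O)c2c1nc1n2[C@H]2OC[C@@H](O)[C@H]2OC1` gives only a limit of the assay, > 16000 nM.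

Compound 3 therefore stands at the weak end of the numbers shown, at the limit of > 16000 nM in this assay, at which 1 of the 3 values shown sits, and its entry is a limit rather than a measured number. Compound 4 `O=C1C(Nc2ccc(C(F)(F)F)cc2)=CC(=O)c2c1nc1n2[C@H]2OC[C@@H](O)[C@H]2OC1` differs from compound 3 by 4-(trifluoromethyl)phenyl in place of cyclopentyl on an amine nitrogen. Among the measured compounds shown here, two measured steps bear on this change, both running the opposite way: an at least 3.5-fold higher number from compound 1 to compound 3 (0.55 log units; beyond the scatter) and an at least 2.4-fold higher number from compound 2 to compound 3 (0.38 log units; beyond the scatter), each beyond the scatter, each showing the cyclopentyl amine weaker than an aryl amine. Compound 1 and compound 2 lie within the scatter of each other, so the substituent pattern on the phenyl is not distinguished here. Putting 4-(trifluoromethyl)phenyl on the amine nitrogen is thus expected to give a lower number in this assay, near the region of compound 1 and compound 2. For compound 4 the expected step is an at least 3.2-fold lower number from compound 3 to compound 4 (0.50 log units; beyond the scatter). Compound 4 is estimated at 5000 nM, with a range from 2000 nM to 16000 nM.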

Compound 4, half-maximal inhibitory concentration: > 4000 nM
Compound 4 gave a limit, no number (the forecaster's own chance of this, stated with the estimate: 15%); the middle value does not contradict the limit.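

In this assay compound 4 gives only a limit, > 4000 nM. Its steps from compound 1, compound 2 and compound 3 therefore cannot be read. The compounds shown leave open whether 4-(trifluoromethyl)phenyl on the amine nitrogen performs like the methoxyphenyl groups of compound 1 and compound 2 or like the cyclopentyl of compound 3.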